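A few compounds are considered here, and "the series" means these few. Any claim that something is new, unique, unknown or untested is made for them only; others in the source may bear on it.

Compound 1 `O=C(O)C[C@H](O)C[C@H](O)CCn1c(C(F)(F)F)nc(-c2ccc(F)cc2)c1-c1ccc(F)cc1` is the reference point of this short series. In an assay on microsomes from liver for inhibition of 3-hydroxy-3-methylglutaryl-coenzyme A reductase (Rattus norvegicus) (a lower number here means a stronger inhibitor, a higher number a weaker inhibitor), compound 1 gives 38 nM, the lowest of the three numbers measured, though compound 2 lies within the scatter of it. Compound 2 `Cc1ccc(-c2nc(C(F)(F)F)n(CC[C@@H](O)C[C@@H](O)CC(=O)O)c2-c2ccc(F)cc2)cc1` gives 43 nM in this assay, and the step of a 1.1-fold higher number from compound 1 to compound 2 (0.05 log units; within the scatter) shows that the exchange of methyl for fluoro on the aromatic carbon leaves the number essentially unchanged. Compound 3 `O=C(O)C[C@H](O)C[C@H](O)CCn1c(C(F)(F)F)nc(-c2ccc(C(F)(F)F)cc2)c1-c1ccc(F)cc1` gives 200 nM; the steps of a 5.3-fold higher number from compound 1 to compound 3 (0.72 log units; beyond the scatter) and a 4.7-fold higher number from compound 2 to compound 3 (0.67 log units; beyond the scatter) are both modest losses and both concern the same aromatic carbon of one of the phenyl rings.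

Compound 4 `CC(C)c1nc(-c2ccc(F)cc2)c(-c2ccc(F)cc2)n1CC[C@@H](O)C[C@@H](O)CC(=O)O` alters a different position of the shared core: isopropyl in place of trifluoromethyl on an aromatic carbon. Going by the values given here, none of the measured steps touches this carbon between the two ring nitrogen atoms, so they bear on the expectation only indirectly, as evidence that the core tolerates small changes without large swings in this assay. On that basis compound 4 is expected to land near compound 1, with the step of a 1.3-fold lower number from compound 1 to compound 4 (0.10 log units; within the scatter) expected to stay within the scatter. The estimate for compound 4 in this assay is therefore 30 nM, with an expected range from 10 nM to 100 nM.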

Compound 4, half-maximal inhibitory concentration: 316 nM
Compound 4: middle estimate off by 11-fold (1.02 log units), on the low side; the whole stated range lies below it.
By their numbers in this assay, from the lowest: compounds 1 and 2 (each within the scatter of the next); then compounds 3 and 4 (each within the scatter of the next).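

Going by these compounds alone, compound 4 gives the first reading at the carbon between two ring nitrogen atoms, and in this assay the exchange of trifluoromethyl for isopropyl there produces an 8.3-fold higher number from compound 1 to compound 4 (0.92 log units; beyond the scatter). The earlier steps shown here all concerned one aromatic carbon of a phenyl ring, where methyl in place of fluoro gave a 1.1-fold higher number from compound 1 to compound 2 (0.05 log units; within the scatter), so that near-silent exchange says nothing general about the shared core: this second position also responds, with trifluoromethyl the group giving the lower number of this pair. The change is also small by the counts, with 4 heavy atoms leaving and 3 entering, neither group bearing a ring, a hydrogen-bond donor or acceptor, or a net charge, yet no evidence is available here to say what lies behind the shift.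

With only two groups shown on this carbon, the compounds leave open how a methyl group, a cyclopropyl ring or an amine there would read in this assay. They also leave open whether the same exchange would give a similar step with the 4-methylphenyl group of compound 2 or the 4-trifluoromethylphenyl group of compound 3 in place of a 4-fluorophenyl group.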